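The source may hold more compounds than are shown below. What is called first, only, known or untested is meant among the compounds shown, and "the series" means these compounds.

Measured so far in a physicochemical assay for solubility, in phosphate buffer, at pH 7.4; a lower number here means a less soluble compound, a higher number a more soluble compound:
- compound 1 `NC(=O)C1CCN(c2nccnc2OC2CN(c3ccc4ccccc4n3)C2)CC1`: 14000 nM
- compound 2 `c1ccc(-c2nccnc2OC2CN(c3ccc4ccccc4n3)C2)cc1`: < 1000 nM

Compound 2 stands at < 1000 nM as a limit of the assay, not a number. On these data alone, this is the limit of < 1000 nM in this assay, at which 1 of the 2 values shown sits, so its true position is unknown.

Compound 3 `Cc1ccc(-c2nccnc2OC2CN(c3ccc4ccccc4n3)C2)cc1` differs from compound 2 by methyl in place of hydrogen on an aromatic carbon, phenyl to 4-methylphenyl methyl in place of hydrogen on an aromatic carbon with the methyl para to a large group.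

For the measured compounds named here, the only measured step, an at least 14-fold lower number from compound 1 to compound 2 (1.14 log units; beyond the scatter), is large, but it exchanges a whole group, phenyl in place of 4-carbamoylpiperidin-1-yl on an aromatic carbon. It bears only indirectly on the addition of one methyl. No step beyond the scatter is therefore expected in this assay, and a report as a limit again is likely.

For compound 3 the estimated value is 600 nM with an expected range of 200 nM to 1500 nM as a working figure. The expected change is a step that the limit leaves unreadable from compound 2 to compound 3 as estimated here.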

Compound 3, solubility: < 1000 nM
Compound 3 ended at the assay's limit; the forecaster's own chance of this, stated with the estimate: 80%; the middle value lies beyond the limit too.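

In this assay compound 3 gives < 1000 nM, which is a limit of the assay and not a number. The change of methyl in place of hydrogen on an aromatic carbon cannot be read, since both ends of that step sit at the same limit: the limit of < 1000 nM in this assay, at which 2 of the 3 values shown sit.

Replacing 4-carbamoylpiperidin-1-yl with 4-methylphenyl gives an at least 14-fold lower number from compound 1 to compound 3 (1.14 log units; beyond the scatter), so the large step seen with phenyl also stands with 4-methylphenyl at this position.

On these data alone, whether the methyl shifts the true value in either direction stays open while both compounds with an aromatic ring at this position lie at the limit. Also open, as far as these compounds go, is how a phenyl carrying an amine or a carboxylic acid, or a morpholine in the same place, would read in this assay, and whether any of these would return a number rather than a limit.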